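Half-life in buffer for three aryl substituent variants

The source may report more compounds than this note shows. Statements on the series, on what has been measured and on what is new or still open speak of the compounds shown alone.

Measured compounds in an ADME assay for pharmacokinetics, read by LC-MS, in phosphate buffer, with a stated time of 72 h, at pH 7.4, tested at 250 uM; a higher number here means that the compound lasts longer, a lower number that the compound disappears faster:
- compound 1 `O=C1C=CC(=O)N1c1cc(C(F)(F)F)cc(C(F)(F)F)c1`: in this assay compound 1 gives < 0.017 h, a limit of the assay (the limit of < 0.017 h in this assay, at which 1 of the 2 values shown sits).
- compound 2 `N#Cc1cc(C(F)(F)F)cc(C(F)(F)F)c1`: in this assay compound 2 gives > 50 h, likewise a limit (the limit of > 50 h in this assay, at which 1 of the 2 values shown sits).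

Among the compounds with values here, only one step between measured compounds exists, an at least 2900-fold higher number from compound 1 to compound 2 (3.46 log units; beyond the scatter). Compound 2 therefore stands at the upper limit of the numbers shown, and since both shown values are limits, its place is known only as being at the top.

Compound 3 `O=C(CBr)c1cc(C(F)(F)F)cc(C(F)(F)F)c1` differs from compound 2 by (bromomethyl)carbonyl in place of cyano on an aromatic carbon. Within the data shown here, no measured step involves the (bromomethyl)carbonyl group itself; the one step that bears on the position, an at least 2900-fold higher number from compound 1 to compound 2 (3.46 log units; beyond the scatter), shows that exchanging the group on this aromatic carbon can move the half-life by a large amount, but it compares the cyano group with a different substituent, not with the one entering here. The expectation for compound 3 is thus a downward step of uncertain size, an at least 5.0-fold lower number from compound 2 to compound 3 (0.69 log units; beyond the scatter), with the estimate for compound 3 being 10 h (range 1 h to 50 h).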

Compound 3, half-life: < 0.017 h
Compound 3 ended at the assay's limit; the forecaster's own chance of this, stated with the estimate: 20%; at least 580-fold (2.76 log units) between middle value and limit.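

Within the data shown here, replacing cyano with (bromomethyl)carbonyl on this aromatic carbon gives an at least 2900-fold lower number from compound 2 to compound 3 (3.46 log units; beyond the scatter) in this assay, so a large drop at this position is no longer seen only with the ring-bearing group of compound 1. The entering group of compound 3 has no ring, yet compound 3 sits at the same assay limit as compound 1, which shows that a ring in the substituent is not required for a result at this limit: the limit of < 0.017 h in this assay, at which 2 of the 3 values shown sit. The step between compound 1 and compound 3 cannot be read, as both values are limits, so the two groups cannot be ranked against each other.

The compounds shown do not separate the carbonyl from the bromine within the entering group, and an acetyl group, which keeps the carbonyl and has no bromine, lies outside this set. From the compounds shown here alone, how compound 3 disappears, what it forms in the buffer and where the actual half-lives of the three compounds lie, all of them being known only as limits, also remain open.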